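The source may report more compounds than this note shows. Statements on the series, on what has been measured and on what is new or still open speak of the compounds shown alone.

Compound 2 `Cc1nc(N(C)C(=O)NC(=O)c2c(F)cccc2F)sc1C(=O)N/N=C/c1ccccc1F` is the reference point of this account. In a functional assay on HepG2 cells (Homo sapiens) for inhibition, read by MTT assay, with a stated time of 72 h (on this read-out lower numbers stand for stronger inhibition and higher numbers for weaker inhibition), compound 2 gives only a limit, > 100 ug/mL. Its nearest neighbour, compound 1 `Cc1nc(N(C)C(=O)NC(=O)c2c(F)cccc2F)sc1C(=O)N/N=C/c1ccc(C(F)(F)F)cc1`, likewise returns only a limit in this assay, > 100 ug/mL. The step that the two limits leave unreadable from compound 1 to compound 2 therefore cannot be read, because both compounds sit at the limit of > 100 ug/mL in this assay, at which 2 of the 3 values shown sit. For the measured compounds named here, compound 3 `CN(C(=O)NC(=O)c1ccccc1F)c1nc(C(F)(F)F)c(C(=O)N/N=C/c2ccccc2C(F)(F)F)s1`, built on a different core, gives 5.39 ug/mL in this assay; no step connects it to compound 2, so its value shows only that a hydrazone of this kind can reach a readable number.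

Compound 4 `Cc1nc(N(C)C(=O)NC(=O)c2c(F)cccc2F)sc1C(=O)N/N=C/c1ccccc1C(F)(F)F` differs from compound 2 by trifluoromethyl in place of fluoro on an aromatic carbon, ortho to a large group. Going by the values given here, no measured step bears directly on this exchange. Among the compounds with values here, the only readable value in the set belongs to compound 3, which shares the 2-(trifluoromethyl)phenyl of compound 4 but not its core. Compound 3 gives 5.39 ug/mL. The step of an at least 2.5-fold lower number from compound 2 to compound 4 (0.39 log units; beyond the scatter) is therefore expected to be poorly defined. Compound 4 is estimated at 40 ug/mL, within the range from 8 ug/mL to 200 ug/mL.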

Compound 4, half-maximal inhibitory concentration: 1.11 ug/mL
For compound 4 the middle estimate is 36-fold (1.56 log units) above the measured one; measured number outside the range, below it.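

On the shared core, the aromatic ring of the hydrazone now yields a readable number: in this assay, trifluoromethyl in place of fluoro on an aromatic carbon, ortho to a large group, gives an at least 90-fold lower number from compound 2 to compound 4 (1.95 log units; beyond the scatter). The exchange of 4-(trifluoromethyl)phenyl for 2-(trifluoromethyl)phenyl gives an at least 90-fold lower number from compound 1 to compound 4 (1.95 log units; beyond the scatter), so on this core the same group returns a readable number in the second arrangement and not in the first. Both steps are lower bounds rather than sizes, because the two starting compounds stand at an assay limit: the limit of > 100 ug/mL in this assay, at which 2 of the 4 values shown sit.

The compounds shown leave open whether chloro, methyl or methoxy on this aromatic carbon would also give a readable number. As far as these compounds go, compound 3 and compound 4 differ in more than one place, so what the core contributes also stays open.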